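Adding a Third Methoxy Group to Compound 1

The source may report more compounds than this note shows. Statements on the series, on what has been measured and on what is new or still open speak of the compounds shown alone.

Three compounds sharing one core were tested in a functional assay on the whole organism (strain albino) for inhibition, with Rattus norvegicus as the target, read by paw edema, with stated times of 30 min and 1 h, at a dose of 0.28 mmol/kg by the oral route; on this read-out lower numbers stand for less inhibition and higher numbers for more inhibition at the one dose given (going by the name of the read-out). Compound 1 `C=CCn1c(SCC(=O)Nc2ccc(C(C)=O)cc2)nnc1-c1ccc(OC)c(OC)c1` gives 56%. Compound 2 `C=CCn1c(SCC(=O)Nc2ccc(/C(C)=N/O)cc2)nnc1-c1ccc(OC)c(OC)c1` gives 53%, and compound 3 `C=CCn1c(SCC(=O)Nc2ccc(C(C)=O)cc2)nnc1-c1ccc(OC)cc1` gives 50%. Compound 1 thus stands at the top of the three numbers, but the step to compound 2 is a number 3 percentage points lower from compound 1 to compound 2 (within the scatter) and the step to compound 3 is a number 6 percentage points lower from compound 1 to compound 3 (within the scatter), so the three numbers cannot be told apart with confidence.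

The step to be considered leads from compound 1 to compound 4 `C=CCn1c(SCC(=O)Nc2ccc(C(C)=O)cc2)nnc1-c1cc(OC)c(OC)c(OC)c1`. The change is methoxy in place of hydrogen on an aromatic carbon. Going by the values given here, the one measured step that bears on it is the removal of a methoxy group from compound 1 to compound 3, which was a number 6 percentage points lower from compound 1 to compound 3 (within the scatter). Adding a methoxy group is the reverse kind of change, and since taking one away moved the number only within the scatter, no step beyond the scatter is expected here either in this assay.

Compound 4 is therefore expected to give 57%, most likely between 45% and 68%. The expected step is a number 1 percentage points higher from compound 1 to compound 4 (within the scatter).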

Compound 4, a percentage reported as inhibition, in the whole organism at one dose (the size of the read-out at that dose, not a potency): 48%
The estimate for compound 4 lay 9 percentage points above the measured number; the range from low to high includes it.
By their numbers in this assay, from the lowest: compounds 4, 3, 2 and 1 (each within the scatter of the next).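

In this assay, placing a methoxy group on this aromatic carbon, ortho to a methoxy group and meta to a large group, gives a number 8 percentage points lower from compound 1 to compound 4 (within the scatter). The earlier compounds shown here showed only what happens when a methoxy group is taken off this ring; this step shows that adding one also stays within the usual scatter, so neither change separates the compounds with confidence. Nothing available here offers an explanation for this result.

From the compounds shown here alone, whether a different group on this carbon, such as an amine, a carboxylic acid or a chlorine atom, would move the number beyond the scatter remains open. A reading at a single dose also leaves open how these compounds would compare at other doses.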